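This account rests on a few compounds, and the source may have more. Where it says the series, first, only, none or still open, it means among the compounds named here.

In an ADME assay on microsomes from liver (Mus musculus) for pharmacokinetics, read by LC-MS, using NADPH, with stated times of 5 min, 15 min and 30 min, tested at 10 uM (on this read-out higher numbers stand for fast clearance and lower numbers for slow clearance), compound 3 (`C[C@H](NC(=O)C1CCOCC1)c1ccc(NC(=O)N2CC(c3ccc(N)nc3)C2)cc1`) gives < 25 mL.min-1.g-1, which is a limit of the assay and not a number. Compound 2 (`C[C@@H](c1ccc(NC(=O)N2CC(c3ccc(N)nc3)C2)cc1)N1Cc2ccccc2C1=O`) gives < 25 mL.min-1.g-1, also a limit. Between these two lies a step that the two limits leave unreadable from compound 2 to compound 3, so it offers no size to build on. Compound 4 (`C[C@H](NC(=O)[C@@H]1CCCN1C)c1ccc(NC(=O)N2CC(c3ccc(N)nc3)C2)cc1`) differs from compound 3 by 1-methylpyrrolidin-2-yl in place of oxan-4-yl on a carbonyl carbon, with 1-methylpyrrolidin-2-yl in place of oxan-4-yl on a carbonyl carbon. Compound 1 (`C[C@H](NC(=O)[C@@H]1CCCN1C)c1ccc(NC(=O)N2CC(c3cccnc3)C2)cc1`) also carries 1-methylpyrrolidin-2-yl on a carbonyl carbon and differs from compound 4 elsewhere. Compound 1 gives a measured 40.8 mL.min-1.g-1. On that single value, a small rise in clearance is expected, estimated as an at least 1.0-fold higher number from compound 3 to compound 4 (0.03 log units; that floor lies within the scatter). For compound 4 the estimated value is 27 mL.min-1.g-1, with an expected range from 14 mL.min-1.g-1 to 45 mL.min-1.g-1.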

Compound 4, intrinsic clearance in microsomes: < 25 mL.min-1.g-1
Compound 4 gave a limit, no number; the forecaster's own chance of this, stated with the estimate: 50%; middle value at least 1.0-fold (0.03 log units) away from the limit.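

Compound 4 shows that 1-methylpyrrolidin-2-yl on a carbonyl carbon, like oxan-4-yl in compound 3, can end at the limit of this assay, a limit and not a number. Amino in place of hydrogen on an aromatic carbon gives the only readable step, an at least 1.6-fold lower number from compound 1 to compound 4 (0.21 log units; that floor lies within the scatter). The steps among compound 2, compound 3 and compound 4 cannot be read, because all three end at one limit: the limit of < 25 mL.min-1.g-1 in this assay, at which 3 of the 4 values shown sit.

As far as these compounds go, how these three compounds rank therefore stays open. So does the effect of a carboxylic acid on that carbonyl carbon, or of a methylamino group in place of amino.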